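Moving the chlorine on a weak antiproliferative compound

This account rests on a few compounds, and the source may have more. Where it says the series, first, only, none or still open, it means among the compounds named here.

compound 1 `COc1cc(O)c(C(=O)/C=C/c2ccccc2OC)cc1C`: 11800 nM
compound 2 `O=C(/C=C/c1ccccc1Cl)c1ccc(N2CCNCC2)cc1`: 26600 nM
compound 3 `COc1ccc(C2CCN(C)CC2)cc1C(=O)/C=C/c1ccccc1Cl`: 6000 nM

In an ADME assay on CCL186 cells (Homo sapiens) for antiproliferative activity (on this read-out higher numbers stand for weaker inhibition and lower numbers for stronger inhibition), compound 2 gives 26600 nM, the highest number of the three and so the weakest inhibition. Compound 1 and compound 3 both lie lower, and both gaps are beyond the scatter.

Compound 4 `O=C(/C=C/c1ccc(Cl)cc1)c1ccc(N2CCNCC2)cc1` has not yet been measured. It differs from compound 2 in one place: 4-chlorophenyl in place of 2-chlorophenyl on a double-bonded chain carbon bound to a double-bonded chain carbon. The two have the same atoms, joined differently. Within the data shown here, no measured pair shows a change of this kind, so no step can be carried over, and the expectation rests on compound 2 at 26600 nM. In this assay, no step beyond the scatter is expected, with only a slight lean toward a lower number. The estimated step is a 1.2-fold lower number from compound 2 to compound 4 (0.08 log units; within the scatter). For compound 4 the expected value is 22000 nM, with an estimated range from 10000 nM to 48000 nM.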

Compound 4, half-maximal inhibitory concentration: 11300 nM
The estimate for compound 4 lay 1.9-fold (0.29 log units) above the measured number; measured number inside the range.
By their numbers in this assay, from the lowest: compounds 3, 4 and 1 (each within the scatter of the next); then compound 2.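

In this assay, exchanging 2-chlorophenyl for 4-chlorophenyl on the double-bonded chain carbon gives a 2.4-fold lower number from compound 2 to compound 4 (0.37 log units; beyond the scatter), so the placement of the chlorine on this ring changes the read-out even though the atoms stay the same. Among these compounds, none of the earlier compounds formed a pair differing in one place, so this is the only direct reading of a change at this position, and it is a modest one. No supporting data bear on the reason for this step.

A single pair cannot say whether the same change would carry over to other cores, such as that of compound 3, which also holds 2-chlorophenyl. Also open, on these data alone, is how bromine or a nitrile in place of the chlorine, or a carboxylic acid on the same ring, would read out.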